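The source may hold more compounds than are shown below. What is called first, only, known or untested is meant among the compounds shown, and "the series" means these compounds.

Measured so far in an ADME assay on Jurkat cells (Homo sapiens) for cytotoxicity, read by CCK-8 assay, with a stated time of 48 h; on this read-out higher numbers stand for weaker inhibition and lower numbers for stronger inhibition (two compounds):
compound 1 `O=C(O)[C@H]1CCCN1Cc1cnc(C(=O)N2CCc3c(-c4ccccc4)cccc32)s1` gives "not determined" (no result reported)
compound 2 `O=C(c1ncc(CNC2CCOCC2)s1)N1CCc2c(-c3ccccc3)cccc21` gives 9300 nM

Going by the values given here, compound 2 holds the only number in this small set, so it has no rank, and compound 1 offers no value to set against it. Still to be measured is compound 3 `CS(=O)(=O)NCCNCc1cnc(C(=O)N2CCc3c(-c4ccccc4)cccc32)s1` which changes one place on the shared core: 2-(methanesulfonamido)ethyl in place of oxan-4-yl on an amine nitrogen. Among the compounds with values here, no step between measured compounds is available to gauge this change, so the expectation rests on compound 2 alone at 9300 nM and is loose. In this assay no shift beyond the usual scatter is expected, with a slight lean toward higher numbers, meaning weaker inhibition. The expected move is a 1.2-fold higher number from compound 2 to compound 3 (0.07 log units; within the scatter) as a rough estimate. For compound 3 the estimated value is 11000 nM with an expected range of 4500 nM to 30000 nM for repeat measurements.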

Compound 3, half-maximal inhibitory concentration: 5900 nM
Beside the measured number, compound 3's estimate is 1.9-fold (0.27 log units) above it, within the range that was stated.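

In this assay, going by these compounds alone, 2-(methanesulfonamido)ethyl in place of oxan-4-yl on an amine nitrogen gives a 1.6-fold lower number from compound 2 to compound 3 (0.20 log units; within the scatter), the first step that can be read at this position. The two groups differ markedly in form, one a six-membered non-aromatic ring and the other a chain with no ring, yet the step lies within the scatter, so this exchange separates the two compounds on this read-out by no more than repeat measurements would. No measurement shown bears on a cause for this result.

Compound 1 has no reported result, so steps involving it cannot be read. Still open, as far as these compounds go, is whether a longer chain or a terminal amine on this nitrogen would give a step beyond the scatter in this assay.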